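The source may hold more compounds than are shown below. What is called first, only, known or untested is meant among the compounds shown, and "the series" means these compounds.

Measured compounds:
Compound 1, `O=C(NCCCCc1ccccc1)c1cccc(C2OCC(=O)N2c2cccc(F)c2)c1` — 25%
Compound 2, `COc1ccccc1N1C(=O)CSC1C(=O)NCCCCc1ccccc1` — 6%
Compound 3, `COc1cc(F)ccc1N1C(=O)CSC1c1cccc(C(=O)NCCCCc2ccccc2)c1` — 34%

In a functional assay on U2OS cells (Homo sapiens) for inhibition, read by CCK-8 assay, with a stated time of 72 h, tested at 1 uM (a higher number here means more inhibition at the concentration tested (going by the name of the read-out), a lower number less inhibition), compound 3 gives 34%, the highest of the three numbers shown. Its nearest neighbour is compound 1, whose value lies lower by an amount within the usual scatter, so the two cannot be ordered against each other. Compound 2 sits furthest away, with a gap beyond the scatter.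

Compound 4, `O=C(NCCCCc1ccccc1)c1cccc(C2SCC(=O)N2c2ccccc2F)c1`, is the compound not yet measured. It keeps the shared core of compound 3 and differs at one place: 2-fluorophenyl in place of 4-fluoro-2-methoxyphenyl on an amide-type nitrogen in a ring

Within the data shown here, no pair of measured compounds differs in only one place, so no single-change step is available to lean on. Compound 2, which also carries an aryl group on the ring nitrogen, gives 6%, but it differs from compound 3 at more than one place and offers no isolated reading of this exchange. The step from compound 3 to compound 4 is therefore expected to be small, a number 10 percentage points lower from compound 3 to compound 4 (within the scatter), most likely within the scatter or slightly downward. Compound 4 is estimated at 24%, with a range from 5% to 45%.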

Compound 4, a percentage reported as inhibition, at one concentration (the size of the read-out at that concentration, not a potency): 38%
Compound 4: middle estimate off by 14 percentage points, on the low side; the range from low to high includes it.
By their numbers in this assay, from the lowest: compound 2; then compounds 1, 3 and 4 (each within the scatter of the next, the first and the last beyond it).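

In this assay, among these compounds, placing 2-fluorophenyl instead of 4-fluoro-2-methoxyphenyl on the amide-type nitrogen gives a number 4 percentage points higher from compound 3 to compound 4 (within the scatter) and supplies the first single-place comparison in this set. For this pair, the aryl group goes from 9 heavy atoms to 7 and from 1 hydrogen-bond acceptor to 0, and the exchange produces no change that can be told from the scatter, so the methoxy group and the 4-fluoro substituent are not needed to retain this level of inhibition at the single concentration tested. Nothing at hand explains why the two compounds read alike.

The compounds shown leave open whether a larger change at this position, such as a morpholine or a carboxylic acid on the aryl ring, would move the number beyond the scatter. They also leave open whether the same exchange would read alike on the core of compound 1, and how compound 3 and compound 4 would compare across a range of concentrations rather than at a single one.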